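Swapping fluoro for ethyl on two related cores

The compounds below may be only part of what the source reports. "The series", "measured", "known", "first", "only" and "open" are said of these compounds alone.

Compound 1 `Fc1cccc2cc(-c3nn[nH]n3)cnc12` was tested in a functional assay on the whole organism (strain Sprague-Dawley) for inhibition, with Rattus norvegicus as the target; on this read-out lower numbers stand for an effect already at smaller amounts and higher numbers for an effect only at larger amounts of compound. In this assay compound 1 gives only a limit, > 10 mg/kg, which is the limit of > 10 mg/kg in this assay, at which 1 of the 3 values shown sits. Compound 2 `CCc1cccc2cc(-c3nn[nH]n3)cnc12` gives 2.5 mg/kg, and the change is ethyl in place of fluoro on an aromatic carbon; this made an at least 4.0-fold lower number from compound 1 to compound 2 (0.60 log units; beyond the scatter). Compound 3 `O=c1c(-c2nn[nH]n2)c[nH]c2ccc(F)cc12` has a different core, and the difference between the two cores is not broken down here. In this assay compound 3 gives 1.25 mg/kg. Compound 4 `CCc1ccc2[nH]cc(-c3nn[nH]n3)c(=O)c2c1` carries the same kind of change, (ethyl in place of fluoro on an aromatic carbon); the place differs, being meta to a fused ring and para to a fused ring rather than ortho to a fused ring and meta to a fused ring. Because the earlier step was an at least 4.0-fold lower number from compound 1 to compound 2 (0.60 log units; beyond the scatter), a lower number is expected here too, with the expected step being a 2.1-fold lower number from compound 3 to compound 4 (0.32 log units; beyond the scatter). For compound 4 the estimated value is 0.6 mg/kg, between 0.15 mg/kg and 2.5 mg/kg.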

Compound 4, minimum effective dose: < 5 mg/kg
Compound 4: only a limit was reported (the forecaster's own chance of this, stated with the estimate: 5%); the middle value is on the limit's open side.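

In this assay, among the compounds shown here, compound 4 gives < 5 mg/kg as a limit, so no step from compound 3 to compound 4 can be read. On these data alone, it stays open whether ethyl in place of fluoro gives a lower number on the core of compound 3, as it does on the core of compound 1.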